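Series notes: side-chain rearrangement from compound 1 to compound 3

The source may report more compounds than this note shows. Statements on the series, on what has been measured and on what is new or still open speak of the compounds shown alone.

Going by the values given here, compound 1 `COC(=O)CN(C)c1nc(NCc2ccccc2)ncc1[N+](=O)[O-]` stands highest of the two numbers measured so far: in a functional assay on A549 cells (Homo sapiens) for antiproliferative activity, read by MTT assay, with a stated time of 48 h (on this read-out higher numbers stand for weaker inhibition and lower numbers for stronger inhibition), compound 1 gives 79400 nM. Compound 2 `COC(=O)CN(C)c1nc(Nc2cccc(OC)c2)ncc1[N+](=O)[O-]` gives 31900 nM in this assay. The step of a 2.5-fold lower number from compound 1 to compound 2 (0.40 log units; beyond the scatter) alters the benzylamino group and so does not bear on the change made here. Compound 3 `CCOC(=O)CNc1nc(NCc2ccccc2)ncc1[N+](=O)[O-]` differs from compound 1 by ((ethoxycarbonyl)methyl)amino in place of ((methoxycarbonyl)methyl)(methyl)amino on an aromatic carbon. Among the compounds with values here, no measured step covers this change, so no shift beyond the scatter in this assay is expected. Compound 3 is estimated at 80000 nM, range 30000 nM to 200000 nM, a step of a 1.0-fold higher number from compound 1 to compound 3 (0.00 log units; within the scatter).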

Compound 3, half-maximal inhibitory concentration: 74400 nM
For compound 3 the middle estimate is 1.1-fold (0.03 log units) above the measured one; the measured number falls inside the stated range.
By their numbers in this assay, from the lowest: compound 2; then compounds 3 and 1 (each within the scatter of the next).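

Going by these compounds alone, the exchange of ((methoxycarbonyl)methyl)(methyl)amino for ((ethoxycarbonyl)methyl)amino on this aromatic carbon in this assay comes to a 1.1-fold lower number from compound 1 to compound 3 (0.03 log units; within the scatter), the first reading at this position. The entering group carries a hydrogen-bond donor that the leaving group lacks, yet the pair cannot separate the loss of the methyl on nitrogen from the change of ester. No evidence on this result is available. Open, going by these compounds, is whether a carboxylic acid or a longer chain at this position would stay within the scatter, and whether 3-methoxyphenyl in place of benzyl would give a similar step on the side chain of compound 3.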